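The source may report more compounds than this note shows. Statements on the series, on what has been measured and on what is new or still open speak of the compounds shown alone.

Compound 1 `N#CC1=C(N)Oc2c(c3nc4ccccc4nc3c3ccccc23)C12C(=O)N(Cc1cnnn1-c1ccc(F)cc1)c1ccccc12`; in an ADME assay on HUVEC cells (Homo sapiens) for antiproliferative activity, read by MTT assay, with a stated time of 48 h (on this read-out lower numbers stand for stronger inhibition and higher numbers for weaker inhibition), compound 1 gives > 50000 nM, a limit of the assay.
Compound 2 `CCOc1ccc(-n2nncc2CN2C(=O)C3(C(C#N)=C(N)Oc4c3c3nc5ccccc5nc3c3ccccc43)c3ccccc32)cc1`; in this assay compound 2 gives > 50000 nM, also a limit.
Compound 3 `N#CC1=C(N)Oc2c(c3nc4ccccc4nc3c3ccccc23)C12C(=O)N(Cc1cnnn1-c1cccc(S(N)(=O)=O)c1)c1ccccc12`; in this assay compound 3 gives 38600 nM.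

Compound 3 thus stands as the only one of the three with an actual number; the other two sit at the limit of > 50000 nM in this assay, at which 2 of the 3 values shown sit. The steps toward it were an at least 1.2-fold lower number from compound 1 to compound 3 (0.11 log units; that floor lies within the scatter) and an at least 1.2-fold lower number from compound 2 to compound 3 (0.11 log units; that floor lies within the scatter), each only a floor within the scatter. Compound 4 `Cc1ccc(-n2nncc2CN2C(=O)C3(C(C#N)=C(N)Oc4c3c3nc5ccccc5nc3c3ccccc43)c3ccccc32)cc1C` is not yet measured. It differs from compound 3 by 3,4-dimethylphenyl in place of 3-sulfamoylphenyl on an aromatic nitrogen. Among the measured compounds shown here, since the 3-sulfamoylphenyl is the one group that separates compound 3 from the two limit compounds, and both steps toward it were small, compound 4 is expected to return toward the limit, a step of about a 1.6-fold higher number from compound 3 to compound 4 (0.19 log units; within the scatter). The estimate for compound 4 in this assay is 60000 nM, between 25000 nM and 150000 nM.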

Compound 4, half-maximal inhibitory concentration: > 50000 nM
Compound 4 was reported as a limit (the forecaster's own chance of this, stated with the estimate: 70%); the middle value is on the limit's open side.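

In this assay, compound 4 gives a limit of the assay, so a carbon-only 3,4-dimethylphenyl on this aromatic nitrogen also yields no actual number. The change from 3-sulfamoylphenyl gives an at least 1.2-fold higher number from compound 3 to compound 4 (0.11 log units; that floor lies within the scatter), so these data establish no real difference between the two groups. The steps from compound 1 and compound 2 to compound 4 cannot be read, and the limit now dominates the series: the limit of > 50000 nM in this assay, at which 3 of the 4 values shown sit.

On these data alone, it remains open whether an amine or a carboxylic acid on this phenyl ring would give a clearly lower number. The compounds shown also leave open whether any group at this position can do so.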